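The source may hold more compounds than are shown below. What is called first, only, known or untested is meant among the compounds shown, and "the series" means these compounds.

Compound 2 `COc1cc(Cl)cc(-c2nn(-c3cccc(NC(=O)Nc4cccc(C(F)(F)F)c4)c3)cc2-c2ccncc2)c1` was tested in a functional assay on OVCAR-8 cells (Homo sapiens) for inhibition, read by sulforhodamine B assay, with a stated time of 48 h, tested at 0.1 uM (a lower number here means a stronger effect, a higher number a weaker effect of the compound at the concentration tested), where compound 2 gives 99%. Within the data shown here, the only other measured compound, compound 1 `COc1cc(Cl)cc(-c2nn(-c3cccc(NC(=O)Nc4ccc(Cl)c(C(F)(F)F)c4)c3)cc2-c2ccncc2)c1`, gives 96% in this assay. The two numbers sit within the scatter of each other, the step being a number 3 percentage points higher from compound 1 to compound 2 (within the scatter), so neither compound can be placed ahead of the other; both lie at a level where the compounds show little effect at the concentration tested. That step exchanges hydrogen for chloro on an aromatic carbon and does not touch the part of the molecule that changes next. Compound 3 `COc1cc(Cl)cc(-c2nn(-c3cccc(NC(=O)c4cccc(C(F)(F)F)c4)c3)cc2-c2ccncc2)c1` differs from compound 2 in one place: 3-(trifluoromethyl)phenyl in place of (3-(trifluoromethyl)phenyl)amino on a carbonyl carbon. Among the measured compounds shown here, no measured step involves the carbonyl carbon or the amide-type nitrogen, so there is no direct precedent for this change, and the only guide is that the two numbers in hand stay close to each other. Compound 3 is therefore expected to shift by a number 2 percentage points lower from compound 2 to compound 3 (within the scatter), which is no step beyond the scatter. Compound 3 is estimated at 97%, with a range from 85% to 106%.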

Compound 3, a percentage reported as activity, at one concentration (the size of the read-out at that concentration, not a potency): 94%
Compound 3: middle estimate off by 3 percentage points, on the high side; the range from low to high includes it.
By their numbers in this assay, from the lowest: compounds 3, 1 and 2 (each within the scatter of the next).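

The carbonyl carbon tolerates the loss of the amino nitrogen in this series: with 3-(trifluoromethyl)phenyl in place of (3-(trifluoromethyl)phenyl)amino, this assay gives a number 5 percentage points lower from compound 2 to compound 3 (within the scatter). Among these compounds, this is the first change at this position, and it removes the nitrogen of the leaving group together with its hydrogen-bond donor, yet the read-out stays where it was, and the same holds against the chloro-bearing group, with a number 2 percentage points lower from compound 1 to compound 3 (within the scatter). Nothing available explains why the read-out holds across this change.

Among the compounds shown here, all three compounds sit at a level of little effect at the concentration tested, so this result shows only that no step leaves the scatter and cannot tell whether the amino nitrogen matters where a compound has a clear effect. Going by these compounds, whether a saturated amine such as piperidine, a longer alkyl chain ending in the same 3-(trifluoromethyl)phenyl, or a carboxylic acid on that ring would move the number in this assay beyond the scatter remains open.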